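The source may report more compounds than this note shows. Statements on the series, on what has been measured and on what is new or still open speak of the compounds shown alone.

Measured compounds:
compound 1, `O=C(Nc1cccc(CNc2nccnc2Cl)c1)NC1CCCC1`, 23400 nM
compound 2, `O=C(Nc1cccc(CNc2nccnc2Cl)c1)Nc1cccc2ccccc12`, 32700 nM

Both compounds share a core and differ only in the group carried by one amide-type nitrogen of the urea. In a functional assay on MGC-803 cells (Homo sapiens) for antiproliferative activity, read by MTT assay, with a stated time of 48 h (a higher number here means a weaker inhibitor, a lower number a stronger inhibitor), compound 1 gives 23400 nM, the lowest of the two numbers. Compound 2 gives 32700 nM, and the gap between compound 1 and compound 2 lies within the usual scatter of this assay, so the two results cannot be told apart in strength.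

Compound 3, `Cc1ccc(NC(=O)Nc2cccc(CNc3nccnc3Cl)c2)cc1`, has not yet been tested in this assay. Compared with compound 1 it carries a different group on the amide-type nitrogen: 4-methylphenyl in place of cyclopentyl on an amide-type nitrogen. Both compound 1 and compound 2 carry their own groups at this position and give numbers within the scatter of each other, so the position appears tolerant of this kind of exchange among the measured examples. The step from compound 1 to compound 3 is therefore expected to be small, in no firm direction, giving an estimated 1.1-fold higher number from compound 1 to compound 3 (0.03 log units; within the scatter). Compound 3 is expected to give about 25000 nM in this assay, within a range of 10000 nM to 60000 nM.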

Compound 3, half-maximal inhibitory concentration: 11900 nM
Beside the measured number, compound 3's estimate is 2.1-fold (0.32 log units) above it, and the stated range covers the measured number.
By their numbers in this assay, from the lowest: compounds 3, 1 and 2 (each within the scatter of the next, the first and the last beyond it).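

In this assay, 4-methylphenyl in place of cyclopentyl gives a 2.0-fold lower number from compound 1 to compound 3 (0.29 log units; within the scatter), so this amide-type nitrogen accepts a six-membered aromatic ring of carbon as well as a five-membered non-aromatic one, with no difference that can be told apart in this pair. Within the data shown here, the change does open a wider view of the position: compound 3 at 11900 nM and compound 2 at 32700 nM are the first pair here to lie beyond the usual scatter of each other, which shows that the group on this nitrogen can shift the number measurably, even though neighbouring results overlap. No independent measurement is available to say what lies behind this difference between the groups.

The compounds shown leave open what the methyl group itself contributes, since plain phenyl, which would separate the methyl from the ring, does not appear among them. They also leave open how this nitrogen responds to an open carbon chain such as n-butyl, or to a ring carrying a carboxylic acid or an amine.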